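Swapping the sulfonyl arm for an acetyl benzyl amide

A few compounds are considered here, and "the series" means these few. Any claim that something is new, unique, unknown or untested is made for them only; others in the source may bear on it.

Three compounds have been measured in a functional assay on the whole organism (artery) for inhibition, with Rattus norvegicus as the target, at a dose of 3 mg/kg by the intraduodenal route; on this read-out higher numbers stand for more inhibition at the one dose given (going by the name of the read-out) and lower numbers for less inhibition:

compound 1, `CCCCc1ccc(CNS(=O)(=O)c2ccccc2)c(=O)n1Cc1ccc(-c2ccccc2-c2nn[nH]n2)cc1`: 25.2%
compound 2, `CCCCc1ccc(CNC(=O)N(C)C)c(=O)n1Cc1ccc(-c2ccccc2-c2nn[nH]n2)cc1`: 28%
compound 3, `CCCCc1ccc(CN(C)S(=O)(=O)c2ccccc2)c(=O)n1Cc1ccc(-c2ccccc2-c2nn[nH]n2)cc1`: 68.7%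

Compound 3 stands highest of the three. Its nearest neighbour is compound 2, with a number 40.7 percentage points higher from compound 2 to compound 3 (beyond the scatter), and its furthest is compound 1, with a number 43.5 percentage points higher from compound 1 to compound 3 (beyond the scatter). Compound 1 and compound 2 are not separated, since a number 2.8 percentage points higher from compound 1 to compound 2 (within the scatter).

Compound 4, `CCCCc1ccc(CN(Cc2ccccc2)C(C)=O)c(=O)n1Cc1ccc(-c2ccccc2-c2nn[nH]n2)cc1`, differs from compound 3 in one place: acetyl(benzyl)amino in place of methyl(phenylsulfonyl)amino on a saturated chain carbon bound to an aromatic carbon. For the measured compounds named here, two measured steps bear on this. The step from compound 1 to compound 3, methyl in place of hydrogen on a sulfonamide nitrogen, was large, and the step from compound 2 to compound 3, methyl(phenylsulfonyl)amino in place of (dimethylcarbamoyl)amino, was equally large. Both point to a nitrogen without hydrogen reading high, which compound 4 keeps. Going by the values given here, no measured step, however, tests acetyl in place of phenylsulfonyl, so the outcome is open. A moderate fall in this assay from compound 3 is expected, with wide uncertainty, as a number 18.7 percentage points lower from compound 3 to compound 4 (beyond the scatter). Compound 4 is therefore estimated at 50%, within a range from 25% to 75%.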

Compound 4, a percentage reported as inhibition, in the whole organism at one dose (the size of the read-out at that dose, not a potency): 76.3%
Estimate against measurement, compound 4: 26.3 percentage points below; measured number above the stated range.
By their numbers in this assay, from the lowest: compounds 1 and 2 (each within the scatter of the next); then compounds 3 and 4 (each within the scatter of the next).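

In this assay the acetyl(benzyl)amino group gives a number 7.6 percentage points higher from compound 3 to compound 4 (within the scatter) and so cannot be told apart from the methyl(phenylsulfonyl)amino group, which shows that a phenylsulfonyl group is not required at this place, on a saturated chain carbon bound to an aromatic carbon, for a high number at this dose. The new group also stands clear of both low compounds, with a number 48.3 percentage points higher from compound 2 to compound 4 (beyond the scatter) and with a number 51.1 percentage points higher from compound 1 to compound 4 (beyond the scatter) as well, so among these four compounds the high numbers go with compounds 3 and 4, whose nitrogen carries no hydrogen, and the low numbers with compounds 1 and 2, whose nitrogen does, with none going against this. No measurement at hand gives a reason for these differences.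

As far as these compounds go, it stays open which part of the new group matters, for instance whether a smaller acetyl(methyl)amino group would read as high as the acetyl(benzyl)amino group. From the compounds shown here alone, it is also open whether a simple dialkylamine or a carboxylic acid on this chain carbon would keep the number up, or whether a nitrogen without hydrogen is enough only when a carbonyl or sulfonyl group sits on it.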